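This account rests on a few compounds, and the source may have more. Where it says the series, first, only, none or still open, it means among the compounds named here.

Compound 1 `CS(=O)(=O)c1ccc(N2N=C(c3ccccc3)CCC2=O)cc1` sits at the bottom of the three measured numbers: in a functional assay on the whole organism (strain Wistar) for inhibition, with Rattus norvegicus as the target, read by paw edema, with stated times of 30 min and 5 h, at a dose of 0.05 mmol/kg by the oral route (on this read-out lower numbers stand for less inhibition and higher numbers for more inhibition at the one dose given (going by the name of the read-out)), compound 1 gives 47.3%. Its nearest neighbour is compound 2 `Cc1cc(O)ccc1C1=NN(c2ccc(S(C)(=O)=O)cc2)C(=O)CC1`, which in this assay gives 52.6%, and the furthest is compound 3 `COc1ccc(C2=NN(c3ccc(S(C)(=O)=O)cc3)C(=O)CC2)cc1OC`, which in this assay gives 82.4%. The change from compound 1 to compound 4 `CS(=O)(=O)c1ccc(N2N=C(c3ccc(Oc4ccccc4)cc3)CCC2=O)cc1` is phenoxy in place of hydrogen on an aromatic carbon, and the place of entry is para to a large group. For the measured compounds named here, the one measured step that bears on it, a number 5.3 percentage points higher from compound 1 to compound 2 (within the scatter), put 4-hydroxy-2-methylphenyl in place of phenyl on a carbon with a double bond to nitrogen and stayed within the scatter. No step is shown for compound 3, but its value stands well above that of compound 1. On this basis a modest rise is expected in this assay, though it may not reach beyond the scatter. Compound 4 is therefore estimated at 58%, within 40% to 78%, an expected step of a number 10.7 percentage points higher from compound 1 to compound 4 (beyond the scatter).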

Compound 4, a percentage reported as inhibition, in the whole organism at one dose (the size of the read-out at that dose, not a potency): 65.7%
Compound 4: middle estimate off by 7.7 percentage points, on the low side, and the stated range covers the measured number.
By their numbers in this assay, from the lowest: compounds 1 and 2 (each within the scatter of the next); then compound 4; then compound 3.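

Phenoxy on the aromatic carbon para to a large group gives the first single change shown to lift the number beyond the scatter: in this assay, the result is a number 18.4 percentage points higher from compound 1 to compound 4 (beyond the scatter), whereas the only earlier step was a number 5.3 percentage points higher from compound 1 to compound 2 (within the scatter). The place therefore accepts an added aromatic ring of 7 heavy atoms with no loss of inhibition at the one oral dose, and the number rises instead. No measurement shown here explains this rise.

From the compounds shown here alone, what remains open is whether the rise depends on the added ring, on the oxygen that links it, or on both. A methoxy group, a benzyl group or an amine on the same carbon would help to separate these possibilities.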